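The source may hold more compounds than are shown below. What is called first, only, known or untested is meant among the compounds shown, and "the series" means these compounds.

Measured so far in a functional assay on HEK293 cells (Homo sapiens) for cytotoxicity; a lower number here means that less compound is tolerated, a higher number that more compound is tolerated:

compound 1, `COc1ccc([C@H]2CC(=O)N(c3cccc(N(C)C)c3)C2)cc1OC1CCCC1`, reported only as a limit, > 10000 nM
compound 2, `COc1ccc([C@H]2CC(=O)N(c3cccc(N)c3C)C2)cc1OC1CCCC1`, reported only as a limit, > 10000 nM
compound 3, `COc1ccc([C@H]2CC(=O)N(c3cccc(C)c3)C2)cc1OC1CCCC1`, reported only as a limit, > 10000 nM

Among the compounds with values here, compound 1 therefore has no exact number in this assay; its result is a limit, and it stands where every value so far stands, (the limit of > 10000 nM in this assay, at which 3 of the 3 values shown sit). Compound 4, `COc1ccc([C@H]2CC(=O)N(c3cccc(S(C)(=O)=O)c3)C2)cc1OC1CCCC1`, has not yet been measured. It differs from compound 1 in one place: methylsulfonyl in place of dimethylamino on an aromatic carbon.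

Two measured steps start from compound 1 and touch the same part of the molecule. From compound 1 to compound 2 the result is a step that the two limits leave unreadable from compound 1 to compound 2, and from compound 1 to compound 3 it is a step that the two limits leave unreadable from compound 1 to compound 3. Neither gives a readable size or direction, because both ends sit at the limit, (the limit of > 10000 nM in this assay, at which 3 of the 3 values shown sit). There is thus no measured step that says how an exchange at this position moves the read-out in this assay, and no reason drawn from these compounds to expect a step beyond the scatter.

Compound 4 is accordingly expected to return a limit again rather than a number, estimated at 10000 nM with a range from 5000 nM to 30000 nM. The step this estimate implies, a number no higher from compound 1 to compound 4 (the limit leaves the size open), is expected to be unreadable in the same way.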

Compound 4, half-maximal cytotoxic concentration: > 10000 nM
Compound 4: no number, only a limit; the forecaster's own chance of this, stated with the estimate: 80%; the middle value sits exactly at the limit.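

In this assay compound 4 gives > 10000 nM, a limit and not a number. Its steps to compound 1, compound 2 and compound 3 cannot be read, because both ends of each step are limits: the limit of > 10000 nM in this assay, at which 4 of the 4 values shown sit. The compounds shown leave open at what concentration any of them harms these cells, and whether exchanging the group on the aromatic carbon changes that concentration at all.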